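This account rests on a few compounds, and the source may have more. Where it says the series, first, only, none or still open, it means among the compounds named here.

Measured so far:
compound 1 `COc1ccc(Sc2ccccc2N2C[C@@H](C)N(CC(=O)O)C[C@@H]2C)cc1` — 160 nM
compound 2 `COc1ccc(Sc2ccccc2N2C[C@H](C)N(CC(=O)O)C[C@H]2C)cc1` — 53000 nM

In an assay for inhibition of sodium- and chloride-dependent glycine transporter 1 (Homo sapiens) (a higher number here means a weaker inhibitor, a lower number a stronger inhibitor), compound 2 gives the highest of the two numbers. Within the data shown here, the only step measured is a 330-fold higher number from compound 1 to compound 2 (2.52 log units; beyond the scatter), which rests on (the fact that compounds 1 and 2 differ only in the configuration as drawn). Compound 3 `COc1ccc(Sc2ccccc2N2C[C@@H](C)N(CC(=O)O)C[C@H]2C)cc1` is next: the two compounds have the same atoms and bonds and differ only in configuration as drawn: 1 of 2 stereo elements differ; a stereocentre at a saturated ring carbon is drawn S in compound 2 and R in compound 3. Only one of the two centres is inverted here, so compound 3 sits between the two measured arrangements, and the large stereochemical sensitivity in this assay argues that it will not match compound 2. A step of an 18-fold lower number from compound 2 to compound 3 (1.25 log units; beyond the scatter) is expected, toward the lower number of compound 1 but not reaching it. For compound 3 the estimate in this assay is 3000 nM, within 400 nM to 25000 nM.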

Compound 3, half-maximal inhibitory concentration: 16000 nM
For compound 3 the middle estimate is 5.3-fold (0.73 log units) below the measured one; the range from low to high includes it.
By their numbers in this assay, from the lowest: compound 1; then compound 3; then compound 2.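

In this assay the two stereocentres at saturated ring carbons do not count equally: inverting one alone already gives a 100-fold higher number from compound 1 to compound 3 (2.00 log units; beyond the scatter). Inverting the other gives only a 3.3-fold lower number from compound 2 to compound 3 (0.52 log units; beyond the scatter). Most of the difference between the mirror images therefore follows one centre, and configuration is the only variable in this comparison: the fact that compounds 1 and 3 differ only in the configuration as drawn

Open, going by these compounds, is how the remaining arrangement of the two centres behaves. Also open, on these data alone, is whether the same preference holds with an amide in place of the carboxylic acid, or with ethyl groups in place of the ring methyl groups.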